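The compounds below may be only part of what the source reports. "The series", "measured", "known", "first", "only" and "open" are said of these compounds alone.

Working notes on the series. Three members have been measured; compound 1 is `O=C(NCc1ccc(F)cc1)c1ccc(N2CCN(S(=O)(=O)c3cccnc3C3CC3)CC2)nn1`, compound 2 is `O=C(NCc1ccc(F)cc1)c1ccc(N2CCN(S(=O)(=O)c3ccccc3C(F)(F)F)CC2)nn1` and compound 3 is `O=C(NCc1ccccc1)c1ccc(N2CCN(S(=O)(=O)c3ccccc3Cl)CC2)nn1`. In an ADME assay on microsomes from liver (Mus musculus) for metabolic stability, read by LC-MS, using NADPH, tested at 10 uM (on this read-out higher numbers stand for a longer-lived compound and lower numbers for a shorter-lived compound), compound 1 gives 0.1 h, in this assay compound 2 gives 0.517 h, and in this assay compound 3 gives 0.0333 h. Compound 2 therefore stands highest of the three numbers: the step to it is a 5.2-fold higher number from compound 1 to compound 2 (0.71 log units; beyond the scatter), and against compound 3 only the two values themselves can be compared, with compound 2 the higher by a wide margin.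

The next member is compound 4, `Nc1ncccc1S(=O)(=O)N1CCN(c2ccc(C(=O)NCc3ccc(F)cc3)nn2)CC1`. Against compound 2 the change is 2-aminopyridin-3-yl in place of 2-(trifluoromethyl)phenyl on a sulfonyl sulfur. For the measured compounds named here, one measured step bears on the same position: a 5.2-fold higher number from compound 1 to compound 2 (0.71 log units; beyond the scatter), where 2-(trifluoromethyl)phenyl replaced 2-cyclopropylpyridin-3-yl on the sulfonyl sulfur. Compound 4 moves away from 2-(trifluoromethyl)phenyl again, toward another six-membered aromatic ring with 1 hetero atom. A lowering is expected because a 5.2-fold higher number from compound 1 to compound 2 (0.71 log units; beyond the scatter) ran in the opposite sense when the same position was changed, though the new group differs from both earlier ones, so a smaller step is assumed. The expected step is a 2.6-fold lower number from compound 2 to compound 4 (0.41 log units; beyond the scatter). Compound 4 is thus estimated at 0.2 h in this assay, within 0.07 h to 0.6 h.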

Compound 4, half-life: 0.317 h
For compound 4 the middle estimate is 1.6-fold (0.20 log units) below the measured one; the range from low to high includes it.
By their numbers in this assay, from the lowest: compound 3; then compound 1; then compounds 4 and 2 (each within the scatter of the next).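

In this assay, for the compounds shown here, 2-aminopyridin-3-yl in place of 2-(trifluoromethyl)phenyl on the sulfonyl sulfur gives a 1.6-fold lower number from compound 2 to compound 4 (0.21 log units; within the scatter), so the two groups cannot be told apart at this position and 2-(trifluoromethyl)phenyl is not the only group seen here at that level. Amino in place of cyclopropyl on an aromatic carbon gives a 3.2-fold higher number from compound 1 to compound 4 (0.50 log units; beyond the scatter), a change beyond the scatter in which only that one group differs, so the low number of compound 1 does not follow from a 2-substituted pyridin-3-yl group as such. Nothing on hand explains either step.

The compounds shown leave open whether the number at this aromatic carbon follows the amino group specifically, as a methylamino, dimethylamino, methoxy or methyl group in its place would test on the otherwise unchanged structure of compound 4. They also leave open how the chloro group of compound 3 would compare with amino or trifluoromethyl, since compound 3 differs from the other compounds in more than one place.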